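Swapping the amide substituent on a trifluoromethoxy thiourea

The source may report more compounds than this note shows. Statements on the series, on what has been measured and on what is new or still open speak of the compounds shown alone.

Measured compounds:
Compound 1, `O=C(NCc1ccccc1)c1cc(Oc2cccc(NC(=S)Nc3cccc(C(F)(F)F)c3)c2)ccn1`: 11000 nM
Compound 2, `O=C(c1cc(Oc2cccc(NC(=S)Nc3cccc(C(F)(F)F)c3)c2)ccn1)N1CCCC1`: 27000 nM
Compound 3, `O=C(NCc1ccccc1)c1cc(Oc2cccc(NC(=S)Nc3ccc(OC(F)(F)F)cc3)c2)ccn1`: 6800 nM

All three were tested in a functional assay on PC-3 cells (Homo sapiens) for cytotoxicity, read by MTT assay, with a stated time of 48 h; on this read-out lower numbers stand for stronger inhibition and higher numbers for weaker inhibition. Compound 1 and compound 2 share one core and differ in a single place: pyrrolidin-1-yl in place of benzylamino on a carbonyl carbon. That change gave a 2.5-fold higher number from compound 1 to compound 2 (0.39 log units; beyond the scatter). Compound 3 is built on a core that differs from that of compound 1 in one place: 4-(trifluoromethoxy)phenyl in place of 3-(trifluoromethyl)phenyl on an amide-type nitrogen. Between these two compounds the numbers are close, since a 1.6-fold lower number from compound 1 to compound 3 (0.21 log units; within the scatter); compound 3 has the lowest number of the three, yet only its gap to compound 2 lies beyond the scatter.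

Compound 4, `O=C(c1cc(Oc2cccc(NC(=S)Nc3ccc(OC(F)(F)F)cc3)c2)ccn1)N1CCCC1`, has not yet been measured in this assay. It relates to compound 3 exactly as compound 2 relates to compound 1: pyrrolidin-1-yl in place of benzylamino on a carbonyl carbon. The place of the change is the same in both pairs, so this is the same change made on a different core.

Because compound 1 to compound 2 gave a 2.5-fold higher number from compound 1 to compound 2 (0.39 log units; beyond the scatter), a step of similar size is expected from compound 3 to compound 4, namely a 2.5-fold higher number from compound 3 to compound 4 (0.40 log units; beyond the scatter). Compound 4 is therefore estimated at 17000 nM, with a plausible range from 8000 nM to 36000 nM; this rests on a single earlier instance and so carries real uncertainty.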

Compound 4, half-maximal inhibitory concentration: 34100 nM
Beside the measured number, compound 4's estimate is 2.0-fold (0.30 log units) below it; low and high end bracket the measured number.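

In this assay, putting pyrrolidin-1-yl in place of benzylamino on the carbonyl carbon gave a 5.0-fold higher number from compound 3 to compound 4 (0.70 log units; beyond the scatter), the same direction as on the first core, and the two steps do not differ measurably: the same change on two cores in this assay, a 2.5-fold higher number (0.39 log units; beyond the scatter) from compound 1 to compound 2 and a 5.0-fold higher number (0.70 log units; beyond the scatter) from compound 3 to compound 4, 2.0-fold (0.31 log units) apart, within the scatter of two such steps

The other change, 4-(trifluoromethoxy)phenyl in place of 3-(trifluoromethyl)phenyl, gave a 1.3-fold higher number from compound 2 to compound 4 (0.10 log units; within the scatter), so neither core shows a real shift from it, and again the two steps agree: the same change on two cores in this assay, a 1.6-fold lower number (0.21 log units; within the scatter) from compound 1 to compound 3 and a 1.3-fold higher number (0.10 log units; within the scatter) from compound 2 to compound 4, 2.0-fold (0.31 log units) apart, within the scatter of two such steps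

Both changes therefore carried over between these two cores, but two pairs cannot show that this will hold on other cores, and they do not explain why the amide change raises the number.

The compounds shown leave open whether the higher numbers go with losing the benzene ring or with losing the amide hydrogen, which a cyclopentylamino group, keeping the hydrogen without the benzene ring, or a benzyl(methyl)amino group, keeping the benzene ring without the hydrogen, could help separate. Also open, on these data alone, is how other groups on the thiourea's phenyl ring, such as a chlorine or a nitrile, would behave.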